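The source may hold more compounds than are shown below. What is called first, only, known or untested is meant among the compounds shown, and "the series" means these compounds.

Measured so far:

Compound 1, `C#CCSc1nc(Nc2cccc(Cl)c2)c(C#N)c(-c2ccccc2)n1`: in a functional assay on ECa-109 cells (Homo sapiens) for inhibition, read by MTT assay, with a stated time of 72 h (on this read-out higher numbers stand for weaker inhibition and lower numbers for stronger inhibition), compound 1 reaches only a limit, > 128000 nM.
Compound 2, `N#Cc1c(Nc2cccc(Cl)c2)nc(SCc2cn(Cc3ccccc3Cl)nn2)nc1-c1ccccc1`: compound 2 gives 24400 nM.
Compound 3, `COc1ccccc1Nc1nc(SCc2cn(Cc3ccccc3Cl)nn2)nc(-c2ccccc2)c1C#N`: compound 3 gives 9670 nM.

Compound 3 stands at the lowest of the two real numbers shown; its nearest neighbour is compound 2, and the only measured single change is a 2.5-fold lower number from compound 2 to compound 3 (0.40 log units; beyond the scatter). The value of compound 1 is a limit of the assay and nothing more (the limit of > 128000 nM in this assay, at which 1 of the 3 values shown sits).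

Compound 4, `N#Cc1c(Nc2ccccc2F)nc(SCc2cn(Cc3ccccc3Cl)nn2)nc1-c1ccccc1`, is the next compound in this series and differs from compound 3 in one place: fluoro in place of methoxy on an aromatic carbon. Within the data shown here, no measured step touches a fluoro group; the one step that has been measured exchanges a whole substituted ring on the same nitrogen and therefore bears on the new change only loosely, showing that the group on that ring can move the number to a modest degree. With nothing closer to lean on, the step of a 1.2-fold higher number from compound 3 to compound 4 (0.09 log units; within the scatter) is expected to stay small, close to or just beyond the scatter, with no firm direction. Compound 4 is thus estimated at 12000 nM, in the range from 4000 nM to 40000 nM.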

Compound 4, half-maximal inhibitory concentration: 23000 nM
Compound 4: the middle estimate sits 1.9-fold (0.28 log units) below what was measured, and the stated range covers the measured number.
By their numbers in this assay, from the lowest: compound 3; then compounds 4 and 2 (each within the scatter of the next). At a limit, above all of these: compound 1.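

In this assay, the exchange at this place, ortho to a large group, does register: fluoro in place of methoxy gives a 2.4-fold higher number from compound 3 to compound 4 (0.38 log units; beyond the scatter), a modest step. The earlier compounds had shown only a change of the whole substituted ring on the nitrogen, whereas this pair isolates the single group on that ring. The second new comparison, a 1.1-fold lower number from compound 2 to compound 4 (0.03 log units; within the scatter), does not separate the 2-fluorophenyl group from the 3-chlorophenyl group, so of the three rings carried on that nitrogen among these compounds, only the 2-methoxyphenyl of compound 3 stands apart, and nothing measured here says what lies behind that difference.

On these data alone, whether this standing belongs to methoxy in particular remains open, since an ethoxy, a hydroxyl or an amine at the same place could fall with compound 3 or with compound 4. Also open, as far as these compounds go, is whether the step between methoxy and fluoro keeps its size once other parts of the shared core change.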